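A few compounds are considered here, and "the series" means these few. Any claim that something is new, unique, unknown or untested is made for them only; others in the source may bear on it.

In a functional assay on SK-MEL-5 cells (Homo sapiens) for cytotoxicity (on this read-out lower numbers stand for higher toxicity in this test and higher numbers for lower toxicity in this test), compound 1 `COc1cccc(-c2nn(-c3ccccc3)cc2-c2ccnc(NCCNC(=O)Nc3cccc(C(F)(F)F)c3)c2)c1` gives 7820 nM.
In this assay compound 2 `O=C(NCCCNc1cc(-c2cn(-c3ccccc3)nc2-c2cccc(O)c2)ccn1)c1ccccc1` gives 6540 nM.

Of the two numbers, that of compound 2 is the lowest, but its gap to compound 1 lies within the usual scatter, so no real separation is shown. Compound 3 `O=C(NCCCNc1cc(-c2cn(-c3ccccc3)nc2-c2cccc(O)c2)ccn1)c1ccc(F)cc1` differs from compound 2 by fluoro in place of hydrogen on an aromatic carbon. Among the compounds with values here, no measured pair shows this change, so in this assay the expected step of a 1.1-fold lower number from compound 2 to compound 3 (0.04 log units; within the scatter) is small, with no direction beyond the scatter. Compound 3 is estimated at 6000 nM, ranging from 2500 nM to 15000 nM.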

Compound 3, concentration lethal to 50% of the cells: 5720 nM
Beside the measured number, compound 3's estimate is 1.0-fold (0.02 log units) above it; the range from low to high includes it.
By their numbers in this assay, from the lowest: compounds 3, 2 and 1 (each within the scatter of the next).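

In this assay, within the data shown here, this is the first comparison of compounds that differ in one place: phenyl becomes 4-fluorophenyl, giving a 1.1-fold lower number from compound 2 to compound 3 (0.06 log units; within the scatter). At this position on the benzamide ring, para to a large group, fluoro in place of hydrogen therefore shows no effect that can be told apart from the scatter. Nothing available explains this result.

Still open, on these data alone, is whether a different group at this same place, such as an amine or a carboxylic acid, would shift the number beyond the scatter.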